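The source may report more compounds than this note shows. Statements on the series, on what has been measured and on what is new or still open speak of the compounds shown alone.

Measured compounds:

- Compound 1, `C=CS(=O)(=O)N1CCN(c2ncnc3ccc(-c4ccccc4)cc23)CC1`: 23400 nM
- Compound 2, `C=CS(=O)(=O)N1CCN(c2nc(OC[C@H]3CCCN3C)nc3sccc23)CC1`: > 50000 nM
- Compound 3, `CCCNC(=O)N1CCN(c2ncnc3sc(-c4ccc(N5CCN(C)CC5)cc4)cc23)CC1`: 12400 nM

All three were tested in a functional assay on MDA-MB-436 cells (Homo sapiens) for antiproliferative activity, read by MTT assay, with a stated time of 48 h; on this read-out higher numbers stand for weaker inhibition and lower numbers for stronger inhibition. Compound 2 gives only a limit there, > 50000 nM, so no number stands for it (the limit of > 50000 nM in this assay, at which 1 of the 3 values shown sits). Compound 3 gives 12400 nM, the lowest of the two numbers shown, but compound 1 with 23400 nM sits within the usual scatter of it, so the two cannot be ordered.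

Compound 4, `CC(C)c1cccc(C(C)C)c1NC(=O)N1CCN(c2ncnc3sc(-c4ccc(N5CCN(C)CC5)cc4)cc23)CC1`, has not yet been measured. It differs from compound 3 in one place: 2,6-diisopropylphenyl in place of propyl on an amide-type nitrogen. Among the measured compounds shown here, no pair of measured compounds differs in just one place, so there is no measured step to lean on, and the size of this change can only be guessed.

The expectation for compound 4 in this assay is a small step, with no clear direction beyond the scatter, a 1.4-fold lower number from compound 3 to compound 4 (0.14 log units; within the scatter). Compound 4 is estimated at 9000 nM, with a range from 2500 nM to 35000 nM.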

Compound 4, half-maximal inhibitory concentration: 11300 nM
Estimate against measurement, compound 4: 1.3-fold (0.10 log units) below; measured number inside the range.
By their numbers in this assay, from the lowest: compounds 4, 3 and 1 (each within the scatter of the next, the first and the last beyond it). At a limit, above all of these: compound 2.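

In this assay, putting 2,6-diisopropylphenyl in place of propyl on the amide-type nitrogen gives a 1.1-fold lower number from compound 3 to compound 4 (0.04 log units; within the scatter). Among the compounds shown here, this is the first measured step at this place, and it shows that a group of 12 heavy atoms with a six-membered aromatic ring and a chain of 3 heavy atoms cannot be told apart on this read-out. Nothing measured here gives a reason for this.

Going by these compounds, both groups contain only carbon, so it remains open whether an amine, a carboxylic acid or a hydroxyl-bearing chain on this nitrogen would shift the number beyond the scatter. On these data alone, it also remains open whether an unsubstituted phenyl would behave like 2,6-diisopropylphenyl, and whether the same swap would give a similar result on a different core.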